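Swapping the Acid-Bearing Aryl Ether for a Methoxyphenyl

A few compounds are considered here, and "the series" means these few. Any claim that something is new, unique, unknown or untested is made for them only; others in the source may bear on it.

Three measured compounds share one core and differ only in the aryl group attached through an oxygen on a saturated carbon. In an assay for positive allosteric modulation of metabotropic glutamate receptor 3 (Rattus norvegicus) (on this read-out lower numbers stand for an effect already at smaller amounts and higher numbers for an effect only at larger amounts of compound), compound 1 `Cc1c(OC[C@@H](C)COc2cc(C(=O)O)ccc2F)ccc(C(=O)CC(C)(C)C)c1O` gives 3950 nM. Compound 2 `Cc1ccc(OC[C@H](C)COc2ccc(C(=O)CC(C)(C)C)c(O)c2C)cc1C(=O)O` is reported in this assay only as a limit, > 10000 nM. Compound 3 `Cc1c(OC[C@@H](C)COc2ccc(C(=O)O)c(Cl)c2)ccc(C(=O)CC(C)(C)C)c1O` gives 860 nM in this assay, the lowest of the two numbers actually given; the step of a 4.6-fold lower number from compound 1 to compound 3 (0.66 log units; beyond the scatter) separates it from compound 1, and the step of an at least 11-fold lower number from compound 2 to compound 3 (1.06 log units; beyond the scatter) from compound 2, while an at least 2.5-fold higher number from compound 1 to compound 2 (0.40 log units; beyond the scatter) ran the other way.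

Compound 4 `COc1ccccc1OC[C@H](C)COc1ccc(C(=O)CC(C)(C)C)c(O)c1C` differs from compound 3 in one place: 2-methoxyphenyl in place of 4-carboxy-3-chlorophenyl on an oxygen on a saturated carbon. Going by the values given here, each measured step exchanged one carboxy-bearing aryl group for another, so the carboxylic acid was kept throughout; this change removes it and brings in a methoxy group, which no measured step covers directly. The measured steps do show that the identity of this aryl group moves the read-out by modest to large amounts. Since every measured compound carries the acid and the lowest number belongs to compound 3 with 860 nM, the expectation for compound 4 is a higher number, a step of a 7.0-fold higher number from compound 3 to compound 4 (0.84 log units; beyond the scatter). Compound 4 is therefore estimated at 6000 nM, within a range from 1500 nM to 25000 nM in this assay.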

Compound 4, half-maximal effective concentration: "not active" (no number reported)
No number was reported for compound 4; there is nothing to compare the estimate with.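

Going by these compounds alone, compound 4 is reported as "not active" with no number, so no step from compound 3 can be read in this assay. Compound 2 also lacks an exact value and is given only as a limit: the limit of > 10000 nM in this assay, at which 1 of the 4 values shown sits. The compounds shown leave open whether the departing carboxy group or the entering methoxy group accounts for the "not active" report.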